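Methoxy Added to the Benzyl Amidine of Compound 2

This account rests on a few compounds, and the source may have more. Where it says the series, first, only, none or still open, it means among the compounds named here.

Of the compounds shown here, two with a shared core have been measured. Compound 1 `COc1ccc(CNC(=N)[C@@H]2CCC(=O)N2Cc2ccc([N+](=O)[O-])cc2)cc1` and compound 2 `N=C(NCc1ccccc1)[C@@H]1CCC(=O)N1Cc1ccc(F)cc1` were both run in a functional assay on SH-SY5Y cells (Homo sapiens) for cytotoxicity, read by MTT assay, with stated times of 8 h, 30 min and 12 h, tested at 0.05 uM; on this read-out higher numbers stand for a stronger effect at the one concentration tested and lower numbers for a weaker effect. In this assay compound 1 gives 14.3%, and in this assay compound 2 gives 13.3%. Compound 2 holds the lower of these two numbers, but the gap to compound 1 lies within the scatter, so the two read as alike. For the measured compounds named here, the two structures differ in more than one place, so no single step between them can be drawn.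

Compound 3 `COc1ccc(CNC(=N)[C@@H]2CCC(=O)N2Cc2ccc(F)cc2)cc1` is not yet measured. It arises from compound 2 by one change: methoxy in place of hydrogen on an aromatic carbon. Going by the values given here, no measured step of this kind exists here, so the step expected in this assay is a number 0.7 percentage points higher from compound 2 to compound 3 (within the scatter), none beyond the scatter. Compound 3 is therefore estimated to give 14% in this assay, with a range from 4% to 26%.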

Compound 3, a percentage reported as activity, at one concentration (the size of the read-out at that concentration, not a potency): 15.8%
The estimate for compound 3 lay 1.8 percentage points below the measured number; low and high end bracket the measured number.
By their numbers in this assay, from the lowest: compounds 2, 1 and 3 (each within the scatter of the next).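

In this assay the benzyl amidine now has a measured step for phenyl to 4-methoxyphenyl, which reads as a number 2.5 percentage points higher from compound 2 to compound 3 (within the scatter) and shows that methoxy on this aromatic carbon, para to a large group, leaves the read-out unmoved. The aromatic carbon that carries nitro in compound 1 also gains a reading for a single change, fluoro in place of nitro, given as a number 1.5 percentage points higher from compound 1 to compound 3 (within the scatter) and likewise no real shift. Nothing available bears on why either change leaves the number in place.

As far as these compounds go, each step rests on one concentration, so how either change behaves at other concentrations remains open. Also open, from the compounds shown here alone, is whether an amine, a carboxylic acid or a longer chain such as butoxy on the same aromatic carbon would move the read-out beyond the scatter.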